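The compounds below may be only part of what the source reports. "The series", "measured", "known", "first", "only" and "open" are said of these compounds alone.

Working notes on the series. In a functional assay on A549 cells (Homo sapiens) for antiproliferative activity, read by MTT assay, with a stated time of 48 h (a higher number here means a weaker inhibitor, a lower number a stronger inhibitor), compound 1 `C=C1/C=C/C(=O)/C(CO)=C\C[C@](C)(CCC=C(C)C)/C=C/[C@H]1OC(=O)C=C(C)C` gives 3090 nM. Compound 2 `CC(C)=CCC[C@]1(C)/C=C/[C@@H](OC(=O)C=C(C)C)[C@](C)(O)/C=C/C(=O)/C(CCl)=C\C1` gives 150 nM in this assay, the lowest of the three numbers, and compound 3 `CC(C)=CCC[C@](C)(/C=C/[C@@H](OC(=O)C=C(C)C)[C@](C)(O)/C=C/C(=O)/C=C/N1CCN(C)CC1)CC=O` gives 2660 nM in this assay; the gap from compound 2 to each of the other two lies beyond the scatter. Compound 4 `CC(C)=CCC[C@]1(C)/C=C/[C@@H](OC(=O)C=C(C)C)[C@](C)(O)/C=C/C(=O)/C(C(=O)N(C)C)=C\C1` is not yet measured. The change from compound 2 to compound 4 is dimethylcarbamoyl in place of chloromethyl on a double-bonded ring carbon. Going by the values given here, no measured pair in the set differs in this one place alone, so the expectation rests on the spread of the three numbers. The step expected here is a 17-fold higher number from compound 2 to compound 4 (1.22 log units; beyond the scatter), upward and beyond the scatter. For compound 4 the estimate in this assay is 2500 nM, with a range from 800 nM to 8000 nM.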

Compound 4, half-maximal inhibitory concentration: 2700 nM
Beside the measured number, compound 4's estimate is 1.1-fold (0.03 log units) below it; the range from low to high includes it.
By their numbers in this assay, from the lowest: compound 2; then compounds 3, 4 and 1 (each within the scatter of the next).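

Going by these compounds alone, this is the first comparison that isolates one place: on the double-bonded ring carbon, in this assay, dimethylcarbamoyl in place of chloromethyl gives an 18-fold higher number from compound 2 to compound 4 (1.26 log units; beyond the scatter). The number at this position therefore depends on the group it carries, and of these two groups chloromethyl gives the lower number. Nothing at hand explains the size of this step.

Going by these compounds, whether the lower number is specific to chloromethyl remains open. A bromomethyl group, an aminomethyl group or a carboxylic acid at this carbon could help settle that.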